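A New Aryl Group at the Assay Limit

A few compounds are considered here, and "the series" means these few. Any claim that something is new, unique, unknown or untested is made for them only; others in the source may bear on it.

Values from a functional assay on HepG2 cells (Homo sapiens) for cytotoxicity, read by MTT assay, with a stated time of 72 h (on this read-out lower numbers stand for stronger inhibition and higher numbers for weaker inhibition), are these
Compound 1 `O=C(Nc1ccc(Oc2ccnc3[nH]ccc23)c(F)c1)c1nn(-c2ccc(Br)cc2)ccc1=O` gives 68000 nM
Compound 2 `Cn1ccc2c(Oc3ccc(NC(=O)c4nn(-c5ccc(Br)cc5)ccc4=O)cc3F)ccnc21` gives > 60000 nM (a limit)

Compound 2 stands at the limit of > 60000 nM in this assay, at which 1 of the 2 values shown sits, and so has a limit, not a number. Compound 3 `Cn1ccc2c(Oc3ccc(NC(=O)c4nn(-c5ccc(Cl)c(C(F)(F)F)c5)ccc4=O)cc3F)ccnc21` has 4-chloro-3-(trifluoromethyl)phenyl in place of 4-bromophenyl on an aromatic nitrogen and is otherwise unchanged. Among the measured compounds shown here, the only measured step (a step that the limit leaves unreadable from compound 1 to compound 2) is unreadable and lies at another place, so no size carries over. No step beyond the scatter is therefore expected in this assay and another limit remains possible. The estimated step is an at least 1.7-fold lower number from compound 2 to compound 3 (0.23 log units; that floor lies within the scatter) at most a small one. For compound 3 the expected value is 35000 nM (estimated range 10000 nM to 100000 nM) in this read-out.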

Compound 3, half-maximal inhibitory concentration: 13500 nM
Compound 3: middle estimate off by 2.6-fold (0.41 log units), on the high side; measured number inside the range.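

Replacing 4-bromophenyl with 4-chloro-3-(trifluoromethyl)phenyl on the aromatic nitrogen gives, in this assay, an at least 4.4-fold lower number from compound 2 to compound 3 (0.64 log units; beyond the scatter), the only readable step shown. Among the compounds shown here, compounds 1 and 2 both carry 4-bromophenyl, so only this change shows that this position can move the value in this assay. The step remains a floor because compound 2 has a limit, not a number: the limit of > 60000 nM in this assay, at which 1 of the 3 values shown sits.

Whether the chlorine or the trifluoromethyl accounts for the step remains open. So does the effect of an amine or a carboxylic acid on this aryl ring.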